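The source may report more compounds than this note shows. Statements on the series, on what has been measured and on what is new or still open speak of the compounds shown alone.

Among the measured compounds shown here, in a functional assay on KYSE-410 cells (Homo sapiens) for antiproliferative activity, read by MTT assay, with a stated time of 72 h (on this read-out higher numbers stand for weaker inhibition and lower numbers for stronger inhibition), compound 2 `COc1ccc(-c2ccc3c(C(=O)Nc4cccc(F)c4)cc(=O)[nH]c3c2)cc1` gives 18000 nM, the only exact number so far. Compound 1 `O=C(Nc1cccc(F)c1)c1cc(=O)[nH]c2cc(-c3ccccc3)ccc12` is recorded only at a limit of the assay, > 20000 nM. For the measured compounds named here, the one measured step, with methoxy in place of hydrogen on an aromatic carbon, is an at least 1.1-fold lower number from compound 1 to compound 2 (0.04 log units; that floor lies within the scatter). As far as these compounds go, it remains open on one side, given (the limit of > 20000 nM in this assay, at which 1 of the 2 values shown sits). Compound 3 `O=C(Nc1cccc(F)c1)c1cc(=O)[nH]c2cc(-c3ccsc3)ccc12` differs from compound 2 in one place, with thiophen-3-yl in place of 4-methoxyphenyl on an aromatic carbon. Going by the values given here, no measured step tests this exchange directly. The nearest guide is the methoxy step an at least 1.1-fold lower number from compound 1 to compound 2 (0.04 log units; that floor lies within the scatter), so no change beyond the scatter is expected in this assay. The expected step is a 1.1-fold higher number from compound 2 to compound 3 (0.05 log units; within the scatter). For compound 3 the estimated value is 20000 nM, with an expected range of 8000 nM to 50000 nM.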

Compound 3, half-maximal inhibitory concentration: 4300 nM
Compound 3: middle estimate off by 4.7-fold (0.67 log units), on the high side; measured number outside the range, below it.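

In this assay, among the compounds shown here, the aromatic carbon carrying the ring substituent proves responsive to the group placed there: thiophen-3-yl in place of 4-methoxyphenyl gives a 4.2-fold lower number from compound 2 to compound 3 (0.62 log units; beyond the scatter), the first step that lies beyond the scatter. As far as these compounds go, with thiophen-3-yl in place of phenyl the change is an at least 4.6-fold lower number from compound 1 to compound 3 (0.66 log units; beyond the scatter), and this step stays open on one side: the limit of > 20000 nM in this assay, at which 1 of the 3 values shown sits. Both steps make compound 3 the most potent of the three compounds shown, so exchanging the six-membered ring for the five-membered one has moved the number where adding methoxy did not.

The compounds shown leave open whether the gain depends on the sulfur, which furan-3-yl or thiophen-2-yl in its place would test. They also leave open how an amine or a carboxylic acid on the thiophene ring would fare.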